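Lengthening a chain where two compounds sit at the limit

The source may hold more compounds than are shown below. What is called first, only, known or untested is meant among the compounds shown, and "the series" means these compounds.

Compound 2 `CCc1ccc(-c2nc(-c3cc(OC)c(OC)c(OC)c3)no2)cc1` stands at the edge of what the assay reports: in a functional assay on cells (Splenocyte, Mus musculus, strain BALB/c) for inhibition, read by scintillation counting and thymidine incorporation, with stated times of 48 h and 8 h (on this read-out lower numbers stand for stronger inhibition and higher numbers for weaker inhibition), compound 2 gives > 50000 nM, which is a limit rather than a number. Compound 1 `COc1cc(-c2noc(-c3ccccc3)n2)cc(OC)c1OC` likewise gives only a limit, > 50000 nM, in this assay. For the measured compounds named here, the one measured step, a step that the two limits leave unreadable from compound 1 to compound 2, cannot be read (the limit of > 50000 nM in this assay, at which 2 of the 2 values shown sit). Compound 3 `CCCCCCc1ccc(-c2nc(-c3cc(OC)c(OC)c(OC)c3)no2)cc1` differs from compound 2 by butyl in place of hydrogen on a saturated chain carbon, two bonds along the chain from an aromatic carbon. Going by the values given here, no measured step speaks to a change of this kind; the expected step is a number no higher from compound 2 to compound 3 (the limit leaves the size open), and a further limit is thought likely. Compound 3 is estimated at 50000 nM, in a range from 10000 nM to 200000 nM.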

Compound 3, half-maximal inhibitory concentration: 23800 nM
For compound 3 the middle estimate is 2.1-fold (0.32 log units) above the measured one; low and high end bracket the measured number.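

Lengthening ethyl to hexyl takes this series off the limit in this assay, giving an at least 2.1-fold lower number from compound 2 to compound 3 (0.32 log units; beyond the scatter). The same chain, set against the compound that carries none, likewise gives an at least 2.1-fold lower number from compound 1 to compound 3 (0.32 log units; beyond the scatter), so this position tolerates a long chain and can show a measurable number. Both steps are minimum sizes, and how large they really are stays open: the limit of > 50000 nM in this assay, at which 2 of the 3 values shown sit.

The compounds shown leave open whether a longer chain than hexyl would lower the number further. They also leave open what an amine or a carboxylic acid in place of the chain would do.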